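Trimming the Amine Tail of a Diaryl Urea

The source may report more compounds than this note shows. Statements on the series, on what has been measured and on what is new or still open speak of the compounds shown alone.

Measured compounds:
compound 1 `CCN(CC)CCn1cnnc1-c1cc(Oc2ccc(NC(=O)Nc3ccccc3C(F)(F)F)cc2F)ccn1` — 11600 nM
compound 2 `CCN(CC)CCn1cnnc1-c1cc(Oc2ccc(NC(=O)Nc3ccc(F)c(F)c3)cc2F)ccn1` — 41300 nM

In a functional assay on MDA-MB-231 cells (Homo sapiens) for antiproliferative activity, read by MTT assay, with a stated time of 72 h (a lower number here means a stronger inhibitor, a higher number a weaker inhibitor), compound 1 gives 11600 nM, the lowest of the two numbers shown. Compound 2 gives 41300 nM. Within the data shown here, the one measured step, a 3.6-fold higher number from compound 1 to compound 2 (0.55 log units; beyond the scatter), swaps the aryl group attached to the urea nitrogen, at the far end of the shared core from the amine tail.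

Compound 3 `CN(C)CCCn1cnnc1-c1cc(Oc2ccc(NC(=O)Nc3ccccc3C(F)(F)F)cc2F)ccn1` differs from compound 1 only in that tail: (dimethylamino)methyl in place of diethylamino on a saturated chain carbon, two bonds along the chain from an aromatic nitrogen. This is a small reshuffling of a flexible, basic side chain, with the same count of hydrogen-bond acceptors and no ring. Among the measured compounds shown here, no measured step touches this chain; the step from compound 1 to compound 2 concerns the urea aryl group and does not bear on it. With nothing pointing either way, compound 3 is expected to stay close to compound 1, with a step of a 1.0-fold higher number from compound 1 to compound 3 (0.01 log units; within the scatter) that does not go beyond the scatter. Compound 3 is therefore estimated at 12000 nM, within a range of 4000 nM to 36000 nM.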

Compound 3, half-maximal inhibitory concentration: 40500 nM
Estimate against measurement, compound 3: 3.4-fold (0.53 log units) below; the whole stated range lies below it.
By their numbers in this assay, from the lowest: compound 1; then compounds 3 and 2 (each within the scatter of the next).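

The amine tail is not a silent part of these molecules: in this assay, the swap of 2-(diethylamino)ethyl for 3-(dimethylamino)propyl gives a 3.5-fold higher number from compound 1 to compound 3 (0.54 log units; beyond the scatter), a step beyond the scatter and towards weaker inhibition. This shows that a change in the tail can matter even when it adds no ring and leaves the counts of hydrogen-bond donors and acceptors in the swapped groups the same. No measurement at hand accounts for the shift.

On these data alone, this one step alters both the chain length and the groups on the amine nitrogen, so their separate contributions remain unknown; a 2-(dimethylamino)ethyl or 3-(diethylamino)propyl tail would pull them apart. Also open, as far as these compounds go, are how a tail ending in a piperidine ring would behave and whether the same tail change has a similar effect with the 3,4-difluorophenyl urea of compound 2.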